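Flavone ether side chain: dioxane ring replaced by dihydroxyethyl

The source may report more compounds than this note shows. Statements on the series, on what has been measured and on what is new or still open speak of the compounds shown alone.

Measured so far in a functional assay on mitochondria (Cricetulus griseus) for inhibition of Monoamine oxidase (Homo sapiens), tested at 0.9 uM; a lower number here means a weaker effect, a higher number a stronger effect of the compound at the concentration tested:
compound 1 `O=c1c(-c2ccc(O)cc2)coc2cc(OCCCCCCBr)ccc12` gives 71.2%.
compound 2 `O=c1c(-c2ccc(O)cc2)coc2cc(OCCC3OCCCO3)ccc12` gives 57.6%.
compound 3 `O=C(O)CCCCCCCCCOc1ccc2c(=O)c(-c3ccc(O)cc3)coc2c1` gives 85.1%.

Compound 2 stands lowest of the three numbers in this assay: the step of a number 13.6 percentage points lower from compound 1 to compound 2 (beyond the scatter) and the step of a number 27.5 percentage points higher from compound 2 to compound 3 (beyond the scatter) both lie beyond the scatter. Compound 4 `O=c1c(-c2ccc(O)cc2)coc2cc(OCC(O)CO)ccc12` differs from compound 2 by a group of 4 heavy atoms (2 carbon, 2 oxygen; no ring) in place of a group of 7 heavy atoms (5 carbon, 2 oxygen; one six-membered non-aromatic ring with 2 hetero atoms), on a saturated chain carbon bound to an oxygen on an aromatic ring. For the measured compounds named here, the two steps that bear on this change both swap the ring group of compound 2 for an open chain and both raise the number, the one from compound 1 read in reverse and a number 27.5 percentage points higher from compound 2 to compound 3 (beyond the scatter); neither entering chain resembles 1,2-dihydroxyethyl, so their bearing is loose. A small rise, possibly within the scatter, is expected. Compound 4 is estimated at 63%, in the range 46% to 79%. The expected step is a number 5.4 percentage points higher from compound 2 to compound 4 (within the scatter).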

Compound 4, a percentage reported as inhibition, at one concentration (the size of the read-out at that concentration, not a potency): 63.8%
For compound 4 the middle estimate is 0.8 percentage points below the measured one, within the range that was stated.
By their numbers in this assay, from the lowest: compounds 2, 4 and 1 (each within the scatter of the next, the first and the last beyond it); then compound 3.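

In this assay the change reads as a number 6.2 percentage points higher from compound 2 to compound 4 (within the scatter) and the swap for the bromo chain as a number 7.4 percentage points lower from compound 1 to compound 4 (within the scatter) and neither step separates the groups. On a saturated chain carbon bound to an oxygen on an aromatic ring, 1,2-dihydroxyethyl therefore cannot be told apart from the ring group of compound 2 or from 5-bromopentyl at this single concentration. No evidence on the cause accompanies this result. Still open, going by these compounds, is whether an amine in place of 1,2-dihydroxyethyl would give a number beyond the scatter of compound 4.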